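The source may hold more compounds than are shown below. What is called first, only, known or untested is meant among the compounds shown, and "the series" means these compounds.

Measured so far:
- compound 1 `CCN1CCN(c2cc(C)c3cc(NC(=O)c4cccnc4)ccc3n2)CC1`: 10600 nM
- compound 2 `Cc1cc(N2CCCC2)nc2ccc(NC(=O)c3ccc(Cl)c(Cl)c3)cc12`: 43400 nM

Both compounds were tested in a functional assay on SK-BR-3 cells (Homo sapiens) for antiproliferative activity, read by MTT assay, with a stated time of 72 h; on this read-out lower numbers stand for stronger inhibition and higher numbers for weaker inhibition. Compound 1 gives 10600 nM, the lower of the two numbers, and compound 2 gives 43400 nM, a gap beyond the usual scatter, so compound 1 is the stronger of the pair on this read-out. Going by the values given here, no step between the two measured compounds is defined, because they differ in more than one place.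

Compound 3 `CCc1ccc(C(=O)Nc2ccc3nc(N4CCN(CC)CC4)cc(C)c3c2)cc1` has not yet been measured. It differs from compound 1 in one place:
4-ethylphenyl in place of pyridin-3-yl on a carbonyl carbon
Among the compounds with values here, nothing among the measured compounds shows how this particular exchange plays out, so the expectation rests on compound 1 alone. The step is expected to be small: the estimated move from compound 1 to compound 3 in this assay is a 1.2-fold higher number from compound 1 to compound 3 (0.09 log units; within the scatter), within or near the scatter. Compound 3 is therefore expected to give about 13000 nM, in a range from 4000 nM to 42000 nM.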

Compound 3, half-maximal inhibitory concentration: 9850 nM
Estimate against measurement, compound 3: 1.3-fold (0.12 log units) above; the measured number falls inside the stated range.
By their numbers in this assay, from the lowest: compounds 3 and 1 (each within the scatter of the next); then compound 2.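

In this assay, the group on the carbonyl carbon can change from pyridin-3-yl to 4-ethylphenyl with a 1.1-fold lower number from compound 1 to compound 3 (0.03 log units; within the scatter) and no real difference in the read-out. For this pair, the ring nitrogen and the hydrogen-bond acceptor it counts as are therefore not required to keep the activity, and a ring of carbon only carrying an ethyl group serves equally well on the core of compound 1. No measurement at hand gives a reason for this lack of change.

Going by these compounds, it remains open whether an amine or a carboxylic acid in place of the ethyl group, or a longer chain there, would move the number beyond the scatter. Compound 2 differs from compound 1 and compound 3 in more than one place, so it cannot show whether this exchange would also leave the number unchanged with a different group on the core.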